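A halogen shift from compound 3 to compound 4

This account rests on a few compounds, and the source may have more. Where it says the series, first, only, none or still open, it means among the compounds named here.

Compound 1 `C[C@]1(CN2CCc3nc(N4CCCCC4)ccc3C2)Cn2cc([N+](=O)[O-])nc2O1`: "not determined" (no result reported)
Compound 2 `C[C@]1(CN2CCc3nc(N4CCC(F)(F)CC4)ccc3C2)Cn2cc([N+](=O)[O-])nc2O1`: "not determined" (no result reported)
Compound 3 `C[C@]1(CN2CCc3nc(-c4cc(Cl)ccc4F)ccc3C2)Cn2cc([N+](=O)[O-])nc2O1`: > 32 ug/mL

The three compounds share one core and were examined in an ADME assay on Vero cells (Chlorocebus sabaeus) for cytotoxicity, read by MTT assay, with a stated time of 72 h; a higher number here means that more compound is tolerated, a lower number that less compound is tolerated. Among the compounds with values here, no result was reported for compound 1 or compound 2, so no step between measured compounds can be read from this set. In this assay compound 3 gives > 32 ug/mL, and this is a limit of the assay, not a number. Within the data shown here, it is the only entry for compound 3, which therefore has no exact value to stand on.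

Compound 4 `C[C@]1(CN2CCc3nc(-c4ccc(Cl)c(F)c4)ccc3C2)Cn2cc([N+](=O)[O-])nc2O1` differs from compound 3 in a single place: 4-chloro-3-fluorophenyl in place of 5-chloro-2-fluorophenyl on an aromatic carbon. It carries 4-chloro-3-fluorophenyl in place of 5-chloro-2-fluorophenyl on an aromatic carbon, next to the ring nitrogen.

The expectation rests on compound 3 alone, whose > 32 ug/mL is a limit. No change beyond the usual scatter is expected, and no direction is favoured; the expected size is a step that the limit leaves unreadable from compound 3 to compound 4. For compound 4 the estimated value in this assay is 40 ug/mL, with an expected range from 16 ug/mL to 64 ug/mL.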

Compound 4, half-maximal cytotoxic concentration: > 32 ug/mL
Compound 4: only a limit was reported; the forecaster's own chance of this, stated with the estimate: 75%; the middle value does not contradict the limit.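

In this assay compound 4 gives > 32 ug/mL, which is a limit and not a number; compound 3 also stands only at a limit, so no step between compound 3 and compound 4 can be read: the limit of > 32 ug/mL in this assay, at which 2 of the 4 values shown sit.

The compounds shown leave open whether 4-chloro-3-fluorophenyl in place of 5-chloro-2-fluorophenyl alters tolerance at all.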